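A few compounds are considered here, and "the series" means these few. Any claim that something is new, unique, unknown or untested is made for them only; others in the source may bear on it.

Measured compounds:
compound 1 `CC(=O)c1cnc(N2CCC(c3coc4c(N5CCc6cc(S(C)(=O)=O)ccc65)ncnc34)CC2)nc1` — 78 nM
compound 2 `CC(C)(C)OC(=O)N1CCC(c2coc3c(N4CC(C)(C)c5cc(S(C)(=O)=O)ccc54)ncnc23)CC1` — "not active" (no number reported)
compound 3 `CC(C)(C)OC(=O)N1CCC(c2coc3c(N4c5ccc(S(C)(=O)=O)cc5CC4(C)C)ncnc23)CC1` — "not active" (no number reported)

Three compounds from this series have been run in a functional assay on cells for agonist activity at Glucose-dependent insulinotropic receptor (Homo sapiens), read by a luciferase reporter, with a stated time of 4 h; a higher number here means that more compound is needed for the effect, a lower number that less compound is needed. Compound 1 is the only one of them with a numerical result: in this assay compound 1 gives 78 nM. Among the compounds with values here, compound 2 is reported in this assay as "not active" (no number reported), and compound 3 likewise as "not active" (no number reported); neither of these two carries a number, so compound 1 stands alone as the single quantitative reference point, and no step between two measured compounds can be drawn.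

The compound to be measured next is compound 4 `CS(=O)(=O)c1ccc2c(c1)CCN2c1ncnc2c(C3CCN(c4ncc(O)cn4)CC3)coc12`. It keeps the whole of compound 1 apart from one group: hydroxy in place of acetyl on an aromatic carbon Cut one bond further out, the same change reads 5-acetylpyrimidin-2-yl to 5-hydroxypyrimidin-2-yl.

Within the data shown here, with no measured pair to anchor the direction, the expectation for compound 4 rests on compound 1 alone. The step from compound 1 to compound 4 in this assay is expected to be a 2.3-fold higher number from compound 1 to compound 4 (0.36 log units; beyond the scatter), a modest loss that could still fall within the usual scatter. Compound 4 is therefore estimated at 180 nM in this assay, with a likely range from 45 nM to 900 nM.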

Compound 4, half-maximal effective concentration: 391 nM
Compound 4: the middle estimate sits 2.2-fold (0.34 log units) below what was measured, within the range that was stated.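

Where the 5-acetylpyrimidin-2-yl group gives way to the 5-hydroxypyrimidin-2-yl group, this assay shows a 5.0-fold higher number from compound 1 to compound 4 (0.70 log units; beyond the scatter) and so gives the series its first step that can be read as a number. It shows that this position, on the six-membered aromatic ring with 2 nitrogen and para to a large group, has a bearing on the result, and that the exchange of acetyl, with 0 hydrogen-bond donors, for the smaller hydroxy, with 1 hydrogen-bond donor, still leaves a numerical result in this assay while the rest of compound 1 stays unchanged. No measurement among those shown bears on why the number moves at this position.

With only two groups at this position carrying values, the compounds shown do not separate what losing the acetyl contributes to the step from what gaining the hydroxy contributes. On these data alone, a methoxy group, an amine or a carboxylic acid in the same place would each test the step further, and how far the change carries over to other compounds also remains open.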